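A few compounds are considered here, and "the series" means these few. Any claim that something is new, unique, unknown or untested is made for them only; others in the source may bear on it.

Working notes on the series. All compounds share a trimethoxyphenyl group and a triazole; the shared core of compound 2 `COc1ccc(Cn2nncc2-c2cc(OC)c(OC)c(OC)c2)cc1N` carries an amino group on a methoxy-bearing ring. In a functional assay on K562 cells (Homo sapiens) for cytotoxicity, read by MTT assay, with a stated time of 5 days (on this read-out lower numbers stand for stronger inhibition and higher numbers for weaker inhibition), compound 2 gives 730 nM. Compound 1 `COc1ccc(Cn2nncc2-c2cc(OC)c(OC)c(OC)c2)cc1[N+](=O)[O-]` differs by nitro in place of amino on an aromatic carbon. For compound 1 this assay reports only a limit, > 10000 nM. The step is an at least 13-fold higher number from compound 2 to compound 1 (1.13 log units; beyond the scatter); its true size is hidden by the limit of > 10000 nM in this assay, at which 2 of the 3 values shown sit.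

Compound 3 `COc1ccc(-c2cn(Cc3cc(OC)c(OC)c(OC)c3)nn2)cc1N` has the same atoms as compound 2 joined differently; the difference between the two cores is not broken down here. For compound 3 this assay again reports only a limit, > 10000 nM.

Compound 4 `COc1ccc(-c2cn(Cc3cc(OC)c(OC)c(OC)c3)nn2)cc1[N+](=O)[O-]` is not yet measured. It differs from compound 3 by nitro in place of amino on an aromatic carbon, the same change as that from compound 2 to compound 1, at a place described in the same words. The expected step is a step that the limit leaves unreadable from compound 3 to compound 4, resting on the limit already reached by compound 3 and on the direction of an at least 13-fold higher number from compound 2 to compound 1 (1.13 log units; beyond the scatter). Compound 4 is expected near 30000 nM in this assay, between 10000 nM and 100000 nM, and most probably reported only as a limit.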

Compound 4, half-maximal inhibitory concentration: > 10000 nM
Compound 4: only a limit was reported; the forecaster's own chance of this, stated with the estimate: 90%; the middle value does not contradict the limit.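

No step can be read from compound 3 to compound 4, because both are reported only as limits: the limit of > 10000 nM in this assay, at which 3 of the 4 values shown sit.

The compounds shown leave open whether nitro in place of amino on an aromatic carbon changes anything on the core of compound 3, and how compound 1, compound 3 and compound 4 rank among themselves in this assay.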